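The compounds below may be only part of what the source reports. "The series", "measured", "known", "first", "only" and "open" are said of these compounds alone.

Measured values in a functional assay for agonist activity at G protein-coupled receptor 88 (Homo sapiens), read by HTRF and cAMP accumulation; on this read-out higher numbers stand for an effect only at larger amounts of compound and lower numbers for an effect already at smaller amounts:
compound 1 `CC(C)[C@H](N)CN(C(=O)[C@@H]1C[C@H]1c1ccccc1)c1ccc(-c2ccccc2)cc1`: 1.1 nM
compound 2 `CC(C)(N)CN(C(=O)[C@@H]1C[C@H]1c1ccccc1)c1ccc(-c2ccccc2)cc1`: 1.4 nM
compound 3 `CC[C@H](C)[C@H](N)CN(C(=O)[C@@H]1C[C@H]1c1ccccc1Cl)c1ccc(-c2ccccc2)cc1`: > 25000 nM

Compound 3 stands apart from the other two. For compound 3 this assay reports only a limit, not a number, (the limit of > 25000 nM in this assay, at which 1 of the 3 values shown sits). Compounds 1 and 2 both give numbers in this assay, and they share an unsubstituted phenyl on the three-membered ring with a chlorine-free acyl part. Going by the values given here, the single measured step, a 1.3-fold higher number from compound 1 to compound 2 (0.10 log units; within the scatter), concerns the saturated chain on the amide-type nitrogen and lies within the scatter; it says nothing about the aryl group on the three-membered ring, which is the site of the change at hand.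

Compound 4 `CC[C@H](C)[C@H](N)CN(C(=O)[C@@H]1C[C@H]1c1cc(F)ccc1F)c1ccc(-c2ccccc2)cc1` differs from compound 3 by 2,5-difluorophenyl in place of 2-chlorophenyl on a saturated ring carbon. Among the compounds with values here, no measured step bears on this exchange, so there is no reference for its direction or size. Compound 4 keeps the chain and the substituted aryl pattern of compound 3, whose reading in this assay is a limit, (the limit of > 25000 nM in this assay, at which 1 of the 3 values shown sits), so compound 4 is expected to stay weak as well. The estimate for compound 4 in this assay is 20000 nM, between 2000 nM and 100000 nM, with a high chance that again only a limit is returned. The expected step is an at least 1.2-fold lower number from compound 3 to compound 4 (0.09 log units; that floor lies within the scatter).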

Compound 4, half-maximal effective concentration: 770 nM
Estimate against measurement, compound 4: 26-fold (1.41 log units) above; measured number outside the range, below it.
By their numbers in this assay, from the lowest: compounds 1 and 2 (each within the scatter of the next); then compound 4. At a limit, above all of these: compound 3.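

The aryl group on the three-membered ring turns out to be a position that responds strongly in this assay: with the saturated chain unchanged, 2,5-difluorophenyl in place of 2-chlorophenyl gives an at least 32-fold lower number from compound 3 to compound 4 (1.51 log units; beyond the scatter). The reading for compound 3 is a limit and not a number, so this step has a floor but no exact size: the limit of > 25000 nM in this assay, at which 1 of the 4 values shown sits. Compound 4 thus shows that a substituted aryl group at this place can still return a number in this assay, which compounds 1 and 2, both with unsubstituted phenyl, could not show.

From the compounds shown here alone, it remains open whether the step follows from the loss of the chlorine or from the entry of the two fluorines; a 2-fluorophenyl and a 2,5-dichlorophenyl at this place would help separate the two. Also open, going by these compounds, is how the aryl group and the chain each contribute to the gap between compound 4 and compounds 1 and 2, which differ from it in more than one place; an unsubstituted phenyl on the chain of compound 4 would link them.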